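The source may hold more compounds than are shown below. What is called first, only, known or untested is meant among the compounds shown, and "the series" means these compounds.

Compound 3 `CC(C)C[C@H](N)c1cc(C(F)(F)F)ccc1N1CCN(C(=O)COc2cccc3ccccc23)CC1` gives 2600 nM in an assay on HEK293 cells for displacement of a labelled ligand from Melanocortin receptor 4 (Homo sapiens) (on this read-out higher numbers stand for weaker inhibition and lower numbers for stronger inhibition), the lowest of the two single numbers recorded there. Its nearest neighbour is compound 2 `CC(C)C[C@H](N)c1cc(C(F)(F)F)ccc1N1CCN(C(=O)CCNC2CCCCC2)CC1`, which gives 4800 nM in this assay; the change a 1.8-fold lower number from compound 2 to compound 3 (0.27 log units; within the scatter) swaps the group on the saturated chain carbon bound to the carbonyl carbon and stays within the scatter. Compound 1 `CC(C)C[C@H](N)c1cc(C(F)(F)F)ccc1N1CCN(C(=O)C(C)Cc2ccc(Cl)c(Cl)c2)CC1` has been measured twice in this assay, giving 120 nM; 1600 nM (2 entries), and the spread between these two entries the several entries of compound 1 in this assay, 120 nM; 1600 nM (2 entries) shows how far repeat measurements of one compound can drift here.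

Compound 4 `CC(C)C[C@H](N)c1cc(C(F)(F)F)ccc1N1CCN(C(=O)CNc2ccccc2)CC1` differs from compound 3 only at that same chain carbon: anilino in place of (naphthalen-1-yl)oxy on a saturated chain carbon bound to a carbonyl carbon. For the measured compounds named here, the one measured step that touches this position, from compound 2 to compound 3, was small, so the exchange of one group for another at this carbon has so far not moved the number beyond the scatter. On that basis compound 4 is expected to sit close to compound 3, with no step beyond the usual scatter, which is what a 1.2-fold higher number from compound 3 to compound 4 (0.06 log units; within the scatter) means. The estimate for compound 4 in this assay is therefore 3000 nM, with a range from 800 nM to 11000 nM.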

Compound 4, inhibition constant: 3600 nM
Compound 4: the middle estimate sits 1.2-fold (0.08 log units) below what was measured, and the stated range covers the measured number.
By their numbers in this assay, from the lowest: compounds 3, 4 and 2 (each within the scatter of the next).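

The exchange of (naphthalen-1-yl)oxy for anilino gives a 1.4-fold higher number from compound 3 to compound 4 (0.14 log units; within the scatter) in this assay, so at this saturated chain carbon bound to a carbonyl carbon, a group with one aromatic ring, fewer heavy atoms and a hydrogen-bond donor gives a number that stays within the scatter of the number for the larger group with two aromatic rings and no donor. For the compounds shown here, the step of a 1.3-fold lower number from compound 2 to compound 4 (0.12 log units; within the scatter) adds a second comparison, this time with (cyclohexylamino)methyl, so compounds 2, 3 and 4 now show three different groups at this carbon with no step among them beyond the scatter. Steps of this size offer no basis for ranking the three groups, and the repeat entries for one compound in this assay show how loosely such numbers are fixed here: the several entries of compound 1 in this assay, 120 nM; 1600 nM (2 entries)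

Going by these compounds, whether a carboxylic acid or a longer chain carrying the anilino group at this carbon would move the number beyond the scatter remains open. On these data alone, compounds 2, 3 and 4 also share the same core, so it is equally open whether these groups would stay this close with a nitrile in place of the trifluoromethyl.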